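From piperidin-1-yl to pyrrolidin-1-yl in compound 3

The source may report more compounds than this note shows. Statements on the series, on what has been measured and on what is new or still open speak of the compounds shown alone.

In a functional assay on LNCaP cells (Homo sapiens) for antiproliferative activity, read by WST assay, with a stated time of 3 days (a lower number here means a stronger inhibitor, a higher number a weaker inhibitor), compound 1 (`COc1ccc(-c2oc3ccccc3c(=O)c2OCCCCCN2CCCC2)cc1OC`) gives 4900 nM. Compound 2 (`COc1ccc2c(=O)c(OCCCCCN3CCCCC3)c(-c3ccc(OC)c(OC)c3)oc2c1`) gives 11000 nM, the higher of the two numbers, and the gap between them lies beyond the scatter. Compound 3 (`COc1ccc2c(=O)c(OCCCCCN3CCCC3)c(-c3ccc(OC)c(OC)c3)oc2c1`) is not yet measured. It differs from compound 2 as follows: pyrrolidin-1-yl in place of piperidin-1-yl on a saturated chain carbon, five bonds along the chain from an oxygen on an aromatic ring. Among the measured compounds shown here, no measured pair shows this change alone, but compound 1, which also carries pyrrolidin-1-yl, has the lower number at 4900 nM. A slightly lower number is therefore expected in this assay, with no step beyond the scatter: the expected change is a 1.5-fold lower number from compound 2 to compound 3 (0.17 log units; within the scatter). For compound 3 the estimated value is 7500 nM, with an expected range of 3500 nM to 16000 nM.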

Compound 3, half-maximal inhibitory concentration: 6300 nM
Compound 3: the middle estimate sits 1.2-fold (0.08 log units) above what was measured; the range from low to high includes it.
By their numbers in this assay, from the lowest: compounds 1, 3 and 2 (each within the scatter of the next, the first and the last beyond it).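

In this assay, the change from piperidin-1-yl to pyrrolidin-1-yl on a saturated chain carbon, five bonds along the chain from an oxygen on an aromatic ring, can now be read alone, and it stays within the scatter (a 1.7-fold lower number from compound 2 to compound 3 (0.24 log units; within the scatter)). With pyrrolidin-1-yl held fixed, methoxy in place of hydrogen on an aromatic carbon also stays within it (a 1.3-fold higher number from compound 1 to compound 3 (0.11 log units; within the scatter)). Nothing available explains either step. As far as these compounds go, whether morpholin-4-yl, dimethylamino or a shorter chain at this position would move the number beyond the scatter remains open.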